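Changing the Amide Substituent of Compound 1

The source may hold more compounds than are shown below. What is called first, only, known or untested is meant among the compounds shown, and "the series" means these compounds.

Measured compounds:
compound 1, `CCN(CC)C(=O)c1ccc(-c2cc(C3=CC(=O)C=CC3=O)no2)s1` — 10000 nM
compound 2, `COc1ccc(OC)c(-c2cc(-c3ccc(C(=O)N(C)C)s3)on2)c1` — > 30000 nM, a limit
compound 3, `COc1ccc(CN(C)C(=O)c2ccc(-c3cc(C4=CC(=O)C=CC4=O)no3)s2)cc1` — > 30000 nM, a limit

All three were tested in a functional assay on A549 cells (Homo sapiens) for cytotoxicity, read by XTT assay, with a stated time of 72 h; a higher number here means a weaker inhibitor, a lower number a stronger inhibitor. Going by the values given here, compound 1 gives 10000 nM and is the only compound for which an actual number is reported. For compound 2 the result is a limit, > 30000 nM. For compound 3 the result is also a limit, > 30000 nM. Together these two results make up (the limit of > 30000 nM in this assay, at which 2 of the 3 values shown sit). So compound 1 stands alone as the one compound with a measurable value, and no pair of measured compounds differs in a single place that would show how any one change shifts the value.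

Compound 4, `O=C1C=CC(=O)C(c2cc(-c3ccc(C(=O)NCC4CC4)s3)on2)=C1`, is not yet measured. It differs from compound 1 by (cyclopropylmethyl)amino in place of diethylamino on a carbonyl carbon. Among the compounds with values here, no measured step covers this kind of change, so there is no basis for expecting a shift in either direction beyond the scatter. The step from compound 1 to compound 4 is therefore expected to be a 1.2-fold higher number from compound 1 to compound 4 (0.08 log units; within the scatter), without a clear direction. Compound 4 is expected to give about 12000 nM in this assay, with a likely range from 3000 nM to 30000 nM.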

Compound 4, half-maximal inhibitory concentration: > 30000 nM
Compound 4: no number, only a limit; the forecaster's own chance of this, stated with the estimate: 35%; at least 2.5-fold (0.39 log units) between middle value and limit.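

Going by these compounds alone, this is the first readable step at this position in this assay: replacing diethylamino with (cyclopropylmethyl)amino on the carbonyl carbon gives an at least 3.0-fold higher number from compound 1 to compound 4 (0.47 log units; beyond the scatter). Even with the same heavy-atom count in both groups, the value at this position responds to what sits on the carbonyl carbon, so this amide substituent cannot be swapped freely here. Compound 4 gives > 30000 nM, which is a limit and not a number, so the step has a lower bound but no known full size, and most of the series sits at this same ceiling: the limit of > 30000 nM in this assay, at which 3 of the 4 values shown sit.

The change brings in the three-membered ring and the amide hydrogen together, and the compounds shown do not separate the two. Going by these compounds, whether ethylamino, with the amide hydrogen but no ring, or a pyrrolidine, with a ring but no amide hydrogen, would stay closer to compound 1 remains open.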